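Swapping a Basic Amine Chain for a Chlorophenoxy Group

A few compounds are considered here, and "the series" means these few. Any claim that something is new, unique, unknown or untested is made for them only; others in the source may bear on it.

In an assay for inhibition of acyl-CoA:cholesterol acyltransferase (Oryctolagus cuniculus), using microsomes (a lower number here means a stronger inhibitor, a higher number a weaker inhibitor), compound 1 `CCCCCCCCCCC(C)(C)C(=O)Nc1c(C)c(N)c(C)c2c1OC(C)(C)C2` gives 59 nM, and in this assay compound 2 `CCCCCCCCCCC1(C(=O)Nc2c(C)cc(C)c3c2OC(C)(C)C3)CCCC1` gives 170 nM. Compound 3 `Cc1cc(C)c(NC(=O)C(C)(C)CCCCCCN2CCCCC2)c2c1CC(C)(C)O2` reaches only the limit of this assay, > 500 nM, so its standing is known just as a limit, as shown by the limit of > 500 nM in this assay, at which 1 of the 3 values shown sits. Compound 4 `Cc1cc(C)c(NC(=O)C(C)(C)CCCCOc2ccc(Cl)cc2)c2c1CC(C)(C)O2` differs from compound 3 in one place: 4-chlorophenoxy in place of 2-(piperidin-1-yl)ethyl on a saturated chain carbon, five bonds along the chain from a carbonyl carbon. Among the measured compounds shown here, no measured pair carries this change, so the size of the step cannot be read from the data; the expectation is that compound 4 falls on the stronger side of the limit set by compound 3, by an estimated step of an at least 1.6-fold lower number from compound 3 to compound 4 (0.22 log units; that floor lies within the scatter). Compound 4 is estimated at 300 nM, with a range from 80 nM to 1500 nM.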

Compound 4, half-maximal inhibitory concentration: 330 nM
Estimate against measurement, compound 4: 1.1-fold (0.04 log units) below; the range from low to high includes it.
By their numbers in this assay, from the lowest: compound 1; then compounds 2 and 4 (each within the scatter of the next). At a limit, above all of these: compound 3.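

Compound 4 gives this place on the chain, five bonds along from a carbonyl carbon, a measured number in this assay, where the 2-(piperidin-1-yl)ethyl chain of compound 3 gave none. Read against that limit, the swap to 4-chlorophenoxy is an at least 1.5-fold lower number from compound 3 to compound 4 (0.18 log units; that floor lies within the scatter). Compound 3 is known only as a limit: the limit of > 500 nM in this assay, at which 1 of the 4 values shown sits.

As far as these compounds go, the true size of the step therefore stays open. So does how a phenoxy group without the chlorine, or a morpholine in place of the piperidine, would read at this place.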